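Aryl Swap on the Azetidinone Core: Weak Antiproliferative Activity

The compounds below may be only part of what the source reports. "The series", "measured", "known", "first", "only" and "open" are said of these compounds alone.

Measured compounds:
compound 1, `COC(=O)/C(=C/c1ccccc1)CN1C(=O)[C@@H](OC)[C@H]1c1ccc(Cl)cc1`, 37900 nM
compound 2, `COC(=O)/C(=C/c1ccccc1)CN1C(=O)[C@@H](OC)[C@H]1c1cccc(F)c1`, 38500 nM

In an ADME assay on cells (Epithelial cell, Homo sapiens) for antiproliferative activity, read by MTT assay, with a stated time of 48 h (a lower number here means a stronger inhibitor, a higher number a weaker inhibitor), compound 1 gives 37900 nM, the lowest of the two numbers, and compound 2 gives 38500 nM. Among the measured compounds shown here, the one measured step, a 1.0-fold higher number from compound 1 to compound 2 (0.01 log units; within the scatter), shows that exchanging the aryl group on the saturated ring carbon left the read-out unchanged within the scatter. Compound 3, `COC(=O)/C(=C/c1ccccc1)CN1C(=O)[C@@H](OC)[C@H]1c1cccc(C(F)(F)F)c1`, has not yet been measured; it differs from compound 1 in one place: 3-(trifluoromethyl)phenyl in place of 4-chlorophenyl on a saturated ring carbon. The step from compound 1 to compound 2 is the only one that bears on this change, and it was flat. For the measured compounds named here, no measured pair shows an effect of a 3-(trifluoromethyl)phenyl group, so the account rests on that single step. The step of a 1.1-fold lower number from compound 1 to compound 3 (0.03 log units; within the scatter) is therefore expected to stay within the scatter. Compound 3 is estimated at 35000 nM, with a range from 15000 nM to 80000 nM.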

Compound 3, half-maximal inhibitory concentration: 71800 nM
Compound 3: middle estimate off by 2.1-fold (0.31 log units), on the low side; measured number inside the range.
By their numbers in this assay, from the lowest: compounds 1, 2 and 3 (each within the scatter of the next).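

With 3-(trifluoromethyl)phenyl, a group of 10 heavy atoms, in place of the 7 heavy atoms of 4-chlorophenyl on the saturated ring carbon, this assay gives a 1.9-fold higher number from compound 1 to compound 3 (0.28 log units; within the scatter), so this exchange, like the earlier aryl swap, does not separate the compounds. Trifluoromethyl in place of fluoro on an aromatic carbon, a change the earlier compounds did not cover, gives a 1.9-fold higher number from compound 2 to compound 3 (0.27 log units; within the scatter), and so all three aryl groups shown lie within the scatter of their neighbours in the ranking. Nothing available offers a reason for these numbers.

The compounds shown leave open whether an aryl group carrying an amine or a carboxylic acid would move the number beyond the scatter at this position. They also leave open whether a change elsewhere, such as a carboxylic acid in place of the methyl ester, would do so.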